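A Further Fluoro on Compound 1

The source may report more compounds than this note shows. Statements on the series, on what has been measured and on what is new or still open speak of the compounds shown alone.

In a functional assay on MCF7 cells (Homo sapiens) for inhibition, in the presence of a further agent that is not named here (on this read-out higher numbers stand for weaker inhibition and lower numbers for stronger inhibition), compound 1 `Nc1ccc(-c2cc(=O)c3c(N)c(F)cc(F)c3o2)cc1F` gives 25 nM, while compound 2 `Cc1ccc(N)c2c(=O)cc(-c3ccc(N)c(F)c3)oc12` gives 180 nM. Compound 1 therefore holds the lower of the two numbers, and the gap between them lies beyond the scatter. Among the measured compounds shown here, no two measured compounds differ in one place only, so the series offers no direct measure of a single change.

Compound 3 `Nc1c(F)cc(-c2cc(=O)c3c(N)c(F)cc(F)c3o2)cc1F` has not yet been measured. It departs from compound 1 in one place: fluoro in place of hydrogen on an aromatic carbon. Fluoro takes the place of hydrogen on an aromatic carbon of a six-membered aromatic ring of carbon only, ortho to an amino group and meta to a fluoro group.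

For the measured compounds named here, with no measured precedent for this change, the expectation is anchored on compound 1 at 25 nM. A small shift towards weaker inhibition is expected, most likely not beyond the scatter. The estimated step is a 1.4-fold higher number from compound 1 to compound 3 (0.15 log units; within the scatter). For compound 3, the expected value is 35 nM, with an estimated range of 10 nM to 120 nM.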

Compound 3, half-maximal inhibitory concentration: 89 nM
The estimate for compound 3 lay 2.5-fold (0.41 log units) below the measured number, within the range that was stated.
By their numbers in this assay, from the lowest: compound 1; then compound 3; then compound 2.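

In this assay, fluoro in place of hydrogen on an aromatic carbon, ortho to an amino group and meta to a fluoro group, gives a 3.6-fold higher number from compound 1 to compound 3 (0.55 log units; beyond the scatter) and so weakens inhibition at this position on the core of compound 1. Among the compounds shown here, this is the first reading of a single change, as compound 1 and compound 2 differ in more than one place and their gap cannot be assigned to any one group; the new step is modest in size but beyond the scatter, so this hydrogen cannot be replaced by fluoro without a measurable loss. The data at hand offer no measurement that accounts for this loss.

Still open, from the compounds shown here alone, is whether the loss is particular to fluoro or also appears with chloro, methyl, methoxy or a nitrile on the same aromatic carbon. For the compounds shown here, the single step also leaves open whether the same change would give a similar shift on the core of compound 2, or with a hydroxyl group in place of the neighbouring amino group.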